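Replacing the fluorinated chain of compound 3

The source may report more compounds than this note shows. Statements on the series, on what has been measured and on what is new or still open speak of the compounds shown alone.

In a functional assay on HL-60 cells (Homo sapiens) for cytotoxicity, read by WST assay, with a stated time of 48 h (a higher number here means a weaker inhibitor, a lower number a stronger inhibitor), compound 1 `COc1cc(C(c2ccc(O)c(OC)c2)[C@H](CF)C(C)C)ccc1O` gives 19000 nM, compound 2 `COc1cc(C(c2ccc(O)c(OC)c2)[C@@H](C)[C@H](C)CF)ccc1O` gives 32000 nM and compound 3 `COc1cc(C(c2ccc(O)c(OC)c2)[C@H](C)[C@@H](C)CF)ccc1O` gives 45000 nM. Compound 3 stands at the high end of these numbers. The measured steps are a 1.7-fold higher number from compound 1 to compound 2 (0.23 log units; within the scatter), a 1.4-fold higher number from compound 2 to compound 3 (0.15 log units; within the scatter), which goes with the fact that compounds 2 and 3 differ only in the configuration as drawn, and a 2.4-fold higher number from compound 1 to compound 3 (0.37 log units; beyond the scatter), the only one beyond the scatter.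

Compound 4 `COc1cc(C(c2ccc(O)c(OC)c2)[C@H](CO)C(C)C)ccc1O` carries this change: 1-(hydroxymethyl)-2-methylpropyl in place of 2-(fluoromethyl)-1-methylpropyl on a saturated chain carbon bound to two aromatic carbons. Among the compounds with values here, no measured step replaces fluoromethyl with hydroxymethyl, so the bearing of these steps is indirect. All are small, and no step beyond the scatter is expected in this assay. The expected change is a 1.3-fold lower number from compound 3 to compound 4 (0.11 log units; within the scatter). For compound 4 the estimated value is 35000 nM, with an expected range of 13000 nM to 90000 nM.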

Compound 4, half-maximal inhibitory concentration: > 100000 nM
Compound 4: a limit, no number; the forecaster's own chance of this, stated with the estimate: 15%; middle value at least 2.8-fold (0.45 log units) away from the limit.
By their numbers in this assay, from the lowest: compounds 1, 2 and 3 (each within the scatter of the next, the first and the last beyond it). At a limit, above all of these: compound 4.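

Compound 4 in this assay gives > 100000 nM, which is a limit and not a number. All three steps to it lie beyond the scatter: an at least 2.2-fold higher number from compound 3 to compound 4 (0.34 log units; beyond the scatter), an at least 3.1-fold higher number from compound 2 to compound 4 (0.49 log units; beyond the scatter) and an at least 5.2-fold higher number from compound 1 to compound 4 (0.72 log units; beyond the scatter). The last, hydroxy in place of fluoro on a saturated chain carbon, is a larger step than any among compounds 1, 2 and 3, so the end of this chain matters more to the reading than the earlier changes suggested.

From the compounds shown here alone, how far compound 4 lies past its limit remains open. So does whether an amine or a carboxylic acid in place of the hydroxy would read like the fluoro compounds or like compound 4.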